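The source may report more compounds than this note shows. Statements on the series, on what has been measured and on what is new or still open speak of the compounds shown alone.

Working notes on the series. Two members have numbers in a functional assay on HT-29 cells (Homo sapiens) for antiproliferative activity, read by MTT assay, with a stated time of 48 h (a lower number here means a stronger inhibitor, a higher number a weaker inhibitor), so far. Compound 1 `N#Cc1ncn(-c2ccc(F)cc2)c1/N=C/c1ccc([N+](=O)[O-])cc1` gives 15900 nM in this assay. Compound 2 `N#Cc1ncn(-c2ccc(F)cc2)c1/N=C/c1ccc(O)cc1` gives 20400 nM in this assay, and the step of a 1.3-fold higher number from compound 1 to compound 2 (0.11 log units; within the scatter) places compound 2 at the higher of the two numbers, though the gap does not rise above the scatter. Compound 3 `COc1ccc(/C=N/c2c(C#N)ncn2-c2ccc(F)cc2)cc1` is next in line and has not yet been measured in this assay. It differs from compound 2 by methyl in place of hydrogen on an oxygen on an aromatic ring, that is, hydroxy to methoxy on the 4-substituted phenyl. Among the measured compounds shown here, no measured step touches that oxygen, and the one step that is known, a 1.3-fold higher number from compound 1 to compound 2 (0.11 log units; within the scatter), exchanged a whole group on that ring without a change beyond the scatter. On that basis the expected step of a 1.1-fold lower number from compound 2 to compound 3 (0.05 log units; within the scatter) is taken to lie within the scatter, with no direction favoured. Compound 3 is therefore estimated at 18000 nM in this assay, with a range from 8000 nM to 45000 nM.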

Compound 3, half-maximal inhibitory concentration: 19400 nM
Estimate against measurement, compound 3: 1.1-fold (0.03 log units) below, and the stated range covers the measured number.
By their numbers in this assay, from the lowest: compounds 1, 3 and 2 (each within the scatter of the next).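

In this assay, among the compounds shown here, the only step at the oxygen itself, hydroxy to methoxy, reads a 1.1-fold lower number from compound 2 to compound 3 (0.02 log units; within the scatter) and stays within the scatter, so methyl in place of hydrogen on this oxygen leaves the number unresolved from that of the hydroxy compound. The second new step, a 1.2-fold higher number from compound 1 to compound 3 (0.09 log units; within the scatter), also stays within the scatter, so nitro, hydroxy and methoxy on this aromatic carbon now all lie within the scatter of one another, and the position shows no separation among these three groups. Nothing available bears on why these numbers lie so close.

The compounds shown leave open whether an amine, a carboxylic acid or a longer alkoxy chain on this aromatic carbon would give a number beyond the scatter. They also leave open whether this closeness holds once another part of the shared core is changed.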